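Swapping a para substituent: from fluoro to piperidinyl

The source may report more compounds than this note shows. Statements on the series, on what has been measured and on what is new or still open speak of the compounds shown alone.

Measured so far:
- compound 1 `Cc1cnc(Nc2ccc([N+](=O)[O-])cc2)nc1Nc1nc2ccccc2s1`: in a functional assay on MDA-MB-231 cells (Homo sapiens) for antiproliferative activity, read by MTT assay, with a stated time of 48 h (a lower number here means a stronger inhibitor, a higher number a weaker inhibitor), compound 1 gives 22500 nM.
- compound 2 `Cc1cnc(Nc2ccc(F)cc2)nc1Nc1nc2ccccc2s1`: in this assay compound 2 gives > 50000 nM, which is a limit of the assay and not a number.

Both compounds share one core and differ only in the group on the outer aromatic ring. Going from the nitro of compound 1 to the fluoro of compound 2 gives an at least 2.2-fold higher number from compound 1 to compound 2 (0.34 log units; beyond the scatter), and compound 2 sits at the limit of > 50000 nM in this assay, at which 1 of the 2 values shown sits.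

Compound 3 `Cc1cnc(Nc2ccc(N3CCCCC3)cc2)nc1Nc1nc2ccccc2s1` is not yet measured. Its change from compound 2 is piperidin-1-yl in place of fluoro on an aromatic carbon. Among the measured compounds shown here, the only measured step touches the same position, and it showed that replacing nitro weakened activity at least modestly; there is no measurement of any piperidin-1-yl group in this set. Compound 3 is therefore expected to remain a weak inhibitor, with an at least 1.4-fold lower number from compound 2 to compound 3 (0.15 log units; that floor lies within the scatter) as the expected step. For compound 3 the estimated value in this assay is 35000 nM, with a plausible range from 8000 nM to 150000 nM.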

Compound 3, half-maximal inhibitory concentration: 37200 nM
Compound 3: the middle estimate sits 1.1-fold (0.03 log units) below what was measured, and the stated range covers the measured number.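

At this aromatic carbon, piperidin-1-yl, with its 6 heavy atoms and one six-membered non-aromatic ring, cannot be told apart from the single-atom-larger picture of nitro only by size: in this assay the comparison gives a 1.7-fold higher number from compound 1 to compound 3 (0.22 log units; within the scatter), so a ring of this size in place of nitro brings no measurable change. Against fluoro the comparison gives an at least 1.3-fold lower number from compound 2 to compound 3 (0.12 log units; that floor lies within the scatter), which means that even the direction of this change is not firmly settled. Compound 2 carries a limit and not a number, so the true size of that step stays unknown: the limit of > 50000 nM in this assay, at which 1 of the 3 values shown sits.

With only nitro, fluoro and piperidin-1-yl shown at this carbon, it remains open whether any group placed here can bring the number far down from this weak range. A morpholine ring, a primary amine or a carboxylic acid at the same carbon could show whether the ring nitrogen of piperidin-1-yl or the ring as a whole matters, and no compound shown separates the two.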